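Carboxy to (4-methoxyphenyl)carbamoyl at the chain end: notes

The compounds below may be only part of what the source reports. "The series", "measured", "known", "first", "only" and "open" are said of these compounds alone.

Measured so far:
compound 1 `O=C(O)CCC(=O)OCCCCCCSc1ccc([N+](=O)[O-])c2nonc12`: 3640 nM
compound 2 `O=C(CCC(=O)OCCCCCCSc1ccc([N+](=O)[O-])c2nonc12)Nc1ccccc1Cl`: 2750 nM

Compound 1 stands at the highest of the two numbers in a functional assay on A549 cells (Homo sapiens) for inhibition, read by MTT assay, with a stated time of 72 h; on this read-out lower numbers stand for stronger inhibition and higher numbers for weaker inhibition; the nearest is compound 2, and the step of a 1.3-fold lower number from compound 1 to compound 2 (0.12 log units; within the scatter) is within the scatter, so the two compounds cannot be put in order.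

Compound 3 `COc1ccc(NC(=O)CCC(=O)OCCCCCCSc2ccc([N+](=O)[O-])c3nonc23)cc1` has not yet been measured. It differs from compound 1 as follows: (4-methoxyphenyl)amino in place of hydroxy on a carbonyl carbon

Among the measured compounds shown here, the only measured step that bears on this is the one from compound 1 to compound 2, where a (2-chlorophenyl)amino group replaced the hydroxy on the same carbonyl carbon and gave a 1.3-fold lower number from compound 1 to compound 2 (0.12 log units; within the scatter), a change within the scatter. Compound 3 carries the same kind of replacement, (4-methoxyphenyl)amino in place of hydroxy, and differs from compound 2 only in the substituent on the aromatic ring. On the evidence of that single step, the step of a 1.2-fold lower number from compound 1 to compound 3 (0.08 log units; within the scatter) is expected to stay within the scatter, with no direction beyond it that the data support. Compound 3 is therefore expected to give about 3000 nM in this assay, with a range from 1200 nM to 7500 nM.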

Compound 3, half-maximal inhibitory concentration: 6480 nM
Compound 3: the middle estimate sits 2.2-fold (0.33 log units) below what was measured; measured number inside the range.
By their numbers in this assay, from the lowest: compounds 2, 1 and 3 (each within the scatter of the next, the first and the last beyond it).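

In this assay, (4-methoxyphenyl)amino in place of hydroxy on the carbonyl carbon gives a 1.8-fold higher number from compound 1 to compound 3 (0.25 log units; within the scatter), so a second aryl amide at this chain end stays level with the free carboxy compound, and the earlier reading from compound 2 no longer rests on a single aryl group. Among the compounds shown here, what the earlier compounds could not show is that the aryl group on the amide-type nitrogen can shift the number: 4-methoxyphenyl in place of 2-chlorophenyl gives a 2.4-fold higher number from compound 2 to compound 3 (0.37 log units; beyond the scatter), a modest step but the only one beyond the scatter, with the aryl pair separated even though neither differs measurably from the carboxy compound 1. No measurement bearing on the reason for this step is available.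

The compounds shown leave open what in the two aryl groups carries the step, a question that an unsubstituted phenyl on the same nitrogen would bear on. Also open, as far as these compounds go, is how a benzyl group on that nitrogen, or a longer chain between the ester and the core, would read in this assay.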